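The compounds below may be only part of what the source reports. "The series", "measured", "known", "first", "only" and "open" are said of these compounds alone.

On these data alone, compound 1 `NCCNc1c(C(=O)NCc2ccc(F)cc2)nc(Br)c2cccnc12` has been run in a toxicity assay on C8166 cells (Homo sapiens) for cytotoxicity, read by MTT assay, with a stated time of 72 h; a higher number here means that more compound is tolerated, a lower number that less compound is tolerated; in this assay compound 1 gives "not determined" (no result reported), so no single number for it has been reported and its standing on this readout is unknown. The one measured relative in the set is compound 2 `O=C(NCc1ccc(F)cc1)c1nc(NCCO)c2cccnc2c1O`; in this assay compound 2 gives 91000 nM, a half-maximal cytotoxic concentration that sits in the range where cells tolerate a good deal of compound before dying.

Compound 3 `O=C(NCc1ccc(F)cc1)c1nc(Br)c2cccnc2c1NCCO` is the target of the step from compound 1. The difference between the two is small: hydroxy in place of amino on a saturated chain carbon, two bonds along the chain from a nitrogen on an aromatic ring. The rest of the shared core, with its bromine and the amide carrying the fluorophenyl group, stays as it is in compound 1.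

Compound 1 gives no number in this assay. Going by the values given here, no measured step can therefore be used as an anchor, and the size of the change from compound 1 to compound 3 cannot be read from the data. Among the compounds with values here, with no measured step to lean on, a move no larger than the usual scatter in this assay is expected in either direction.

For compound 3 the half-maximal cytotoxic concentration in this assay is estimated at 60000 nM, with a range from 20000 nM to 150000 nM.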

Compound 3, half-maximal cytotoxic concentration: 232000 nM
Compound 3: the middle estimate sits 3.9-fold (0.59 log units) below what was measured, and the stated range ends below it.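

Going by these compounds alone, compound 1 has no number in this assay, so no step from compound 1 to compound 3 can be read. The compounds shown leave open how far, and in which direction, putting hydroxy in place of amino shifts the tolerated concentration. No supporting measurement bears on the value for compound 3.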